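Pyrrolidin-1-yl to piperidin-1-yl in compound 3

A few compounds are considered here, and "the series" means these few. Any claim that something is new, unique, unknown or untested is made for them only; others in the source may bear on it.

Within the data shown here, in a functional assay on MCF7 cells (Homo sapiens) for antiproliferative activity, read by MTT assay, with a stated time of 48 h (a lower number here means a stronger inhibitor, a higher number a weaker inhibitor), compound 3 (`O=C(CN1CCCC1)Nc1ccc2ncnc(Nc3ccc(Cl)cc3)c2c1`) gives 16000 nM as the only true number so far. Compound 1 (`O=C(CN1CCCCC1)Nc1ccc2ncnc(Nc3cccc(C(F)(F)F)c3)c2c1`) shows > 100000 nM as a limit of the assay. Compound 2 (`O=C(CN1CCCCC1)Nc1ccc2ncnc(Nc3cccc(Cl)c3)c2c1`) shows > 100000 nM as a limit too. Among the measured compounds shown here, the one measured step is a step that the two limits leave unreadable from compound 1 to compound 2 and offers no size to carry over. For the measured compounds named here, the change to compound 4 (`O=C(CN1CCCCC1)Nc1ccc2ncnc(Nc3ccc(Cl)cc3)c2c1`) is piperidin-1-yl in place of pyrrolidin-1-yl on a saturated chain carbon bound to a carbonyl carbon and no measured step covers it. Compound 2 also bears piperidin-1-yl and has its limit of > 100000 nM so a weakening, not a gain, is expected. The expected step is a 2.5-fold higher number from compound 3 to compound 4 (0.40 log units; beyond the scatter) in this assay with wide uncertainty. For compound 4 the estimate is 40000 nM with an expected range from 12000 nM to 100000 nM.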

Compound 4, half-maximal inhibitory concentration: > 100000 nM
Compound 4 ended at the assay's limit; the forecaster's own chance of this, stated with the estimate: 30%; middle value at least 2.5-fold (0.39 log units) away from the limit.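

In this assay piperidin-1-yl in place of pyrrolidin-1-yl on a saturated chain carbon bound to a carbonyl carbon gives an at least 6.2-fold higher number from compound 3 to compound 4 (0.79 log units; beyond the scatter) with the 4-chlorophenyl group unchanged. Among these compounds, this is the only readable step, and it gives a minimum size only. The steps from compound 1 and compound 2 to compound 4 cannot be read because all three compounds stand at one limit: the limit of > 100000 nM in this assay, at which 3 of the 4 values shown sit.

Going by these compounds, it remains open whether a morpholin-4-yl or dimethylamino group in the same place would match compound 3 or fall to that limit.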